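The source may report more compounds than this note shows. Statements on the series, on what has been measured and on what is new or still open speak of the compounds shown alone.

Compound 1 `O=C(NCc1ccc(S(=O)(=O)c2ccccc2)cc1)N1CCc2ccncc2C1`: > 2000 nM
Compound 2 `O=C(NCc1ccc(S(=O)(=O)c2cc(F)cc(F)c2)cc1)N1Cc2ccncc2C1`: 6.3 nM

In a functional assay on A2780 cells (Homo sapiens) for cytotoxicity, read by sulforhodamine B assay, with a stated time of 72 h (on this read-out higher numbers stand for weaker inhibition and lower numbers for stronger inhibition), compound 1 gives > 2000 nM, which is a limit of the assay and not a number. Among the measured compounds shown here, compound 2, at 6.3 nM, holds the only exact number so far. Compound 3 `O=C(NCc1ccc(S(=O)(=O)C2CCC(F)(F)CC2)cc1)N1Cc2ccncc2C1` carries 4,4-difluorocyclohexyl in place of 3,5-difluorophenyl on a sulfonyl sulfur. The six-membered ring is therefore no longer aromatic. For the measured compounds named here, no measured pair shows this swap, so the expectation is tentative: a modest weakening, meaning a higher number in this assay, with an estimated step of a 2.4-fold higher number from compound 2 to compound 3 (0.38 log units; beyond the scatter). For compound 3 the estimated value is 15 nM, with an expected range of 3 nM to 80 nM.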

Compound 3, half-maximal inhibitory concentration: 13 nM
Compound 3: the middle estimate sits 1.2-fold (0.06 log units) above what was measured, and the stated range covers the measured number.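

Replacing the aromatic ring on the sulfonyl sulfur with a non-aromatic one gives a 2.1-fold higher number from compound 2 to compound 3 (0.31 log units; beyond the scatter) in this assay, a modest loss. Compound 3 still reads 13 nM, so an aromatic ring at this position is not needed for activity in the nanomolar range. Nothing shown here explains the size of this step.

As far as these compounds go, it remains open how a plain cyclohexyl ring without fluorine would behave at this position. A ring containing nitrogen or oxygen, such as piperidine or tetrahydropyran, also remains untested in the compounds shown.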